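The compounds below may be only part of what the source reports. "The series", "measured", "known", "first", "only" and "open" are said of these compounds alone.

Of the compounds shown here, three have been measured in a functional assay on the whole organism (S2 cells, strain S2) for inhibition, with Drosophila as the target, read by a luciferase reporter, with stated times of 1.5 h and 8 h; a lower number here means a stronger inhibitor, a higher number a weaker inhibitor. Compound 1 `CCCC(=O)c1c(OC)c(Cl)c(OC)c(Cl)c1OC` gives 20800 nM. Compound 2 `CCCCC(=O)c1c(OC)c(Cl)c(OC)c(Cl)c1OC` gives 23500 nM; the change between the two is methyl in place of hydrogen on a saturated chain carbon, three bonds along the chain from a carbonyl carbon, and the step is a 1.1-fold higher number from compound 1 to compound 2 (0.05 log units; within the scatter). Compound 3 `CCCCCCCC(=O)c1c(O)c(Cl)c(O)c(Cl)c1O` gives 3700 nM, the lowest of the three numbers, with the steps to both other compounds beyond the scatter; the difference between its core and the core of compound 1 is not broken down here.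

Compound 4 `CCCCCCCCC(=O)c1c(O)c(Cl)c(O)c(Cl)c1O` is not yet measured. Its change from compound 3 is methyl in place of hydrogen on a saturated chain carbon, seven bonds along the chain from a carbonyl carbon. This is the same kind of change as that from compound 1 to compound 2, not the same one: the place differs, three bonds along the chain from a carbonyl carbon in the measured pair, seven bonds along the chain from a carbonyl carbon here. For the measured compounds named here, for compound 4 the expected step is no change at the digits printed from compound 3 to compound 4 (within the scatter), since the one comparable step a 1.1-fold higher number from compound 1 to compound 2 (0.05 log units; within the scatter) lies within the scatter. Compound 4 is therefore estimated to give 3700 nM, with an expected range from 1500 nM to 9000 nM.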

Compound 4, half-maximal inhibitory concentration: 6500 nM
The estimate for compound 4 lay 1.8-fold (0.24 log units) below the measured number; the range from low to high includes it.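

In this assay, methyl in place of hydrogen on a saturated chain carbon, seven bonds along the chain from a carbonyl carbon, gives a 1.8-fold higher number from compound 3 to compound 4 (0.24 log units; within the scatter). Set beside the earlier step on the other core, at a different place on the chain, the change shows no detectable difference between the two cores: the same change on two cores in this assay, a 1.1-fold higher number (0.05 log units; within the scatter) from compound 1 to compound 2 and a 1.8-fold higher number (0.24 log units; within the scatter) from compound 3 to compound 4, 1.6-fold (0.19 log units) apart, within the scatter of two such steps This shows only that one added methyl stays within the scatter on each of these two cores in this single assay; it does not show that the cores would respond alike to a larger change, nor does it give a direction for chain length.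

The compounds shown leave open how a much longer chain, or a chain ending in an amine or a carboxylic acid, would read on either core. Also open, as far as these compounds go, is what the same chain would give when carried on both cores, which would allow the cores themselves to be compared directly.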